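The source may hold more compounds than are shown below. What is called first, only, known or untested is meant among the compounds shown, and "the series" means these compounds.

Compound 2 `O=c1[nH]/c(=C\c2ccco2)c(=O)[nH]/c1=C\c1cccc(Oc2ccc(F)cc2)c1` is the reference point. In a functional assay on NCI-H460 cells (Homo sapiens) for cytotoxicity, read by MTT assay, with a stated time of 72 h (on this read-out lower numbers stand for stronger inhibition and higher numbers for weaker inhibition), compound 2 gives 155 nM, the lowest of the two numbers shown. Compound 3 `CC(C)(C)S(=O)(=O)OCc1ccc(/C=c2\[nH]c(=O)/c(=C/c3cccc(Oc4ccc(F)cc4)c3)[nH]c2=O)o1` gives 378 nM in this assay, a step of a 2.4-fold higher number from compound 2 to compound 3 (0.39 log units; beyond the scatter). Compound 1 `O=c1[nH]/c(=C\c2cccc(Oc3ccc(F)cc3)c2)c(=O)[nH]/c1=C\c1cccnc1` gives a limit of the assay in this assay, > 1000 nM. The step of an at least 6.4-fold lower number from compound 1 to compound 2 (0.80 log units; beyond the scatter) is accordingly known only as a bound (the limit of > 1000 nM in this assay, at which 1 of the 3 values shown sits). The unmeasured compound 4 `O=c1[nH]/c(=C\c2cc3ccccc3o2)c(=O)[nH]/c1=C\c1cccc(Oc2ccc(F)cc2)c1` differs from compound 2 in one place (1-benzofuran-2-yl in place of furan-2-yl on a double-bonded chain carbon bound to an aromatic carbon). Going by the values given here, no measured step swaps one ring for a larger fused ring; the closest is the modest step of a 2.4-fold higher number from compound 2 to compound 3 (0.39 log units; beyond the scatter), where a group was added on the same furan-2-yl. For compound 4 a small shift toward a higher number is expected, a 1.6-fold higher number from compound 2 to compound 4 (0.21 log units; within the scatter), likely within the scatter. Compound 4 is estimated at 250 nM, between 80 nM and 800 nM.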

Compound 4, half-maximal inhibitory concentration: 347 nM
Compound 4: the middle estimate sits 1.4-fold (0.14 log units) below what was measured; low and high end bracket the measured number.
By their numbers in this assay, from the lowest: compound 2; then compounds 4 and 3 (each within the scatter of the next). At a limit, above all of these: compound 1.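

Replacing furan-2-yl with 1-benzofuran-2-yl, which adds a six-membered aromatic ring of carbon only, gives a 2.2-fold higher number from compound 2 to compound 4 (0.35 log units; beyond the scatter). So this place accepts a fused ring at a modest cost, and furan-2-yl stays ahead of it. Compared with pyridin-3-yl, the same group gives an at least 2.8-fold lower number from compound 1 to compound 4 (0.45 log units; beyond the scatter), a step known only as a bound, since compound 1 stands at a limit: the limit of > 1000 nM in this assay, at which 1 of the 4 values shown sits.

The compounds shown leave open how an amine or a carboxylic acid on the furan-2-yl would read. Going by these compounds, a saturated ring such as cyclohexyl at this place also remains open.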